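Carboxy to Dimethylcarbamoyl: What Tolerance to Expect

The compounds below may be only part of what the source reports. "The series", "measured", "known", "first", "only" and "open" are said of these compounds alone.

Measured so far in an ADME assay on HEp-2 cells (Homo sapiens) for cytotoxicity; a lower number here means that less compound is tolerated, a higher number that more compound is tolerated:
- compound 1 `COc1cc(=O)n(Cc2nc3ccccc3n2CCCCF)c2ccccc12` gives 59500 nM.
- compound 2 `CC1(C)C(=O)N(Cc2nc3ccccc3n2CCCC#N)c2ccccc21` gives > 100000 nM.
- compound 3 `CC(C)CCn1c(CN2C(=O)C(CC(=O)O)c3ccccc32)nc2ccccc21` gives 16500 nM.

The result of compound 2 is a limit of this assay, not a number: the limit of > 100000 nM in this assay, at which 1 of the 3 values shown sits. Of the two numbers, compound 3 has the lowest; compound 1 sits beyond the scatter above it. Compound 4 `CC(C)CCn1c(CN2C(=O)C(CC(=O)N(C)C)c3ccccc32)nc2ccccc21` is not yet measured. It differs from compound 3 in one place: dimethylamino in place of hydroxy on a carbonyl carbon. Within the data shown here, no measured pair shows this change, so the expected size of the step rests on judgement alone. A step from compound 3 to compound 4 of a 1.7-fold lower number from compound 3 to compound 4 (0.22 log units; within the scatter) is expected, towards a lower number. Compound 4 is estimated at 10000 nM, between 3000 nM and 40000 nM.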

Compound 4, half-maximal cytotoxic concentration: 4670 nM
Beside the measured number, compound 4's estimate is 2.1-fold (0.33 log units) above it; the measured number falls inside the stated range.
By their numbers in this assay, from the lowest: compound 4; then compound 3; then compound 1. At a limit, above all of these: compound 2.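

Replacing hydroxy with dimethylamino on this carbonyl carbon is not a neutral change: this assay shows a 3.5-fold lower number from compound 3 to compound 4 (0.55 log units; beyond the scatter), so the amide is tolerated less well than the carboxylic acid on this core. Among these compounds, this rests on a single pair, so it describes only this position and this core. Nothing shown here accounts for the size or direction of the step.

As far as these compounds go, it remains open whether a primary amide, a methyl ester or a longer chain at this position would shift the number the same way. From the compounds shown here alone, it is also open whether the same change would have a similar effect on the core of compound 1.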